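The source may report more compounds than this note shows. Statements on the series, on what has been measured and on what is new or still open speak of the compounds shown alone.

Measured so far:
Compound 1, `C=C(C)Cn1cc(CO[C@H]2CC(=O)[C@@H]3OC[C@H]2O3)nn1` — 17200 nM in a functional assay on HT-29 cells (Homo sapiens) for cytotoxicity, read by MTT assay, with a stated time of 48 h; a higher number here means a weaker inhibitor, a lower number a stronger inhibitor
Compound 2, `O=C1C[C@H](OCc2cc(/C=C/c3ccccc3)no2)[C@H]2CO[C@@H]1O2` — 13700 nM in the same assay

In this assay compound 2 and compound 1 give numbers that lie within the scatter of each other, so the two cannot be told apart. Compound 3, `O=C1C[C@H](OCc2cc(C3CCCCC3)no2)[C@H]2CO[C@@H]1O2`, has not yet been measured; it differs from compound 2 in one place: cyclohexyl in place of 2-phenylethenyl on an aromatic carbon. Among the measured compounds shown here, no measured pair shows what such a change does here, so there is no basis for expecting a step beyond the scatter in either direction. Compound 3 is therefore estimated at 18000 nM, in the range 7000 nM to 45000 nM, which would mean a step of a 1.3-fold higher number from compound 2 to compound 3 (0.12 log units; within the scatter).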

Compound 3, half-maximal inhibitory concentration: 9000 nM
The estimate for compound 3 lay 2.0-fold (0.30 log units) above the measured number, within the range that was stated.
By their numbers in this assay, from the lowest: compounds 3, 2 and 1 (each within the scatter of the next).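

In this assay, putting cyclohexyl in place of 2-phenylethenyl on this aromatic carbon, next to the ring nitrogen, gives a 1.5-fold lower number from compound 2 to compound 3 (0.18 log units; within the scatter) and so stays within the scatter. At this position, then, a non-aromatic ring of carbon only and an aromatic ring held on a double bond cannot be told apart in this assay. Nothing available explains why the two replacements read alike.

Still open, on these data alone, is whether an amine, a carboxylic acid or a longer carbon chain on this same carbon would shift the number beyond the scatter.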